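Pyridin-2-yl for Thiophen-2-yl: Expecting Compound 4

The compounds below may be only part of what the source reports. "The series", "measured", "known", "first", "only" and "open" are said of these compounds alone.

Compound 2 `Oc1cccc(-c2cc(-c3ccc(Cl)cc3)nc(-c3cccs3)c2)c1` stands second highest of the three numbers in an assay on isolated protein for inhibition of DNA topoisomerase 1 (Homo sapiens), with a stated time of 30 min, tested at 100 uM (a higher number here means a stronger effect of the compound at the concentration tested, a lower number a weaker effect), where compound 2 gives 15.1%. Its nearest neighbour is compound 1 `Oc1ccc(-c2cc(-c3ccccc3)nc(-c3ccccc3Cl)c2)cc1`, which in this assay gives 13.6%, within the scatter of compound 2. Furthest from it is compound 3 `Oc1ccc(-c2cc(-c3ccc(Cl)cc3)nc(-c3cccs3)c2)cc1`, which in this assay gives 38.8%; the one measured step, a number 23.7 percentage points higher from compound 2 to compound 3 (beyond the scatter), is modest and concerns the hydroxyphenyl group alone. Compound 4 `Oc1cccc(-c2cc(-c3ccc(Cl)cc3)nc(-c3ccccn3)c2)c1` differs from compound 2 in a different way: pyridin-2-yl in place of thiophen-2-yl on an aromatic carbon. Among the measured compounds shown here, no measured pair shows this exchange, so the step from compound 2 to compound 3 does not bear on it directly, and nothing in the three numbers points in either direction. The step is therefore expected to stay within the scatter, a number 0.1 percentage points lower from compound 2 to compound 4 (within the scatter). For compound 4 the expected value in this assay is 15%, with a range from 3% to 32%.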

Compound 4, a percentage reported as inhibition, at one concentration (the size of the read-out at that concentration, not a potency): 30%
Compound 4: middle estimate off by 15 percentage points, on the low side; low and high end bracket the measured number.
By their numbers in this assay, from the lowest: compounds 1 and 2 (each within the scatter of the next); then compounds 4 and 3 (each within the scatter of the next).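

In this assay, the aromatic carbon next to the ring nitrogen proves responsive to the group it carries: pyridin-2-yl in place of thiophen-2-yl gives a number 14.9 percentage points higher from compound 2 to compound 4 (beyond the scatter), whereas the earlier measured step concerned only the hydroxyphenyl group. The two groups have the same counts of hydrogen-bond donors and acceptors and no net charge, so those counts do not separate them; they differ in ring size and hetero atom. Nothing available bears on why the number rises.

The compounds shown leave open whether the same exchange would raise the number when the hydroxyl group sits on the 4-hydroxyphenyl group of compound 3. They also leave open how a plain phenyl, a furan-2-yl or a morpholine would fare at this position.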